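The compounds below may be only part of what the source reports. "The series", "measured", "known", "first", "only" and "open" are said of these compounds alone.

Measured compounds:
compound 1 `COc1cc(C)cc(-c2c(-c3ccnc(-c4ccc(C(C)=O)cc4)c3)cnn2CC#N)c1` — 101%
compound 2 `Cc1cc(O)cc(-c2nn(CC#N)cc2-c2ccnc(-c3ccc(Oc4ccccc4)cc3)c2)c1` — 90%
compound 3 `COc1cc(C)cc(-c2nn(CC#N)cc2-c2ccnc(-c3ccc(N(C)C)cc3)c2)c1` — 103%

In a functional assay on RXF 393 cells (Homo sapiens) for cytotoxicity, read by sulforhodamine B assay, with a stated time of 48 h, tested at 0.01 uM (on this read-out higher numbers stand for a weaker effect at the one concentration tested and lower numbers for a stronger effect), compound 3 gives 103%, the highest of the three numbers. Compound 1 sits close, within the scatter, while compound 2 lies beyond the scatter below compound 3. For the measured compounds named here, no pair differs in one place only, so the separate contributions cannot be read off.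

Compound 4 `Cc1cc(O)cc(-c2nn(CC#N)cc2-c2ccnc(-c3ccc(N(C)C)cc3)c2)c1` is not yet measured. It differs from compound 3 by hydrogen in place of methyl on an oxygen on an aromatic ring. Compound 2 also carries the hydroxy, yet differs in a second place, so its lower number offers no clean guide. At this single concentration the step is expected to be small, at most a modest decrease: a number 6 percentage points lower from compound 3 to compound 4 (within the scatter). Compound 4 is estimated at 97%, between 84% and 108%.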

Compound 4, a percentage reported as activity, at one concentration (the size of the read-out at that concentration, not a potency): 104%
Compound 4: middle estimate off by 7 percentage points, on the low side; the measured number falls inside the stated range.
By their numbers in this assay, from the lowest: compound 2; then compounds 1, 3 and 4 (each within the scatter of the next).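

In this assay, the change from methoxy to hydroxy on the aromatic ring leaves the read-out level, a number 1 percentage points higher from compound 3 to compound 4 (within the scatter), so at this one concentration the free hydroxy makes no visible difference when dimethylamino is present. The second pair separates the other site: dimethylamino in place of phenoxy on an aromatic carbon gives a number 14 percentage points higher from compound 2 to compound 4 (beyond the scatter), so the lower number of compound 2 goes with the phenoxy rather than the hydroxy. No available evidence bears on either step.

Going by these compounds, what an ethoxy group or an amine in place of the hydroxy would give in this assay stays open. So does whether either step holds at another concentration.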